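The compounds below may be only part of what the source reports. "The series", "measured", "known", "first", "only" and "open" are said of these compounds alone.

Working notes on the series. In an assay on HEK293 cells for inhibition of Voltage-dependent T-type calcium channel subunit alpha-1G (Homo sapiens) (a lower number here means a stronger inhibitor, a higher number a weaker inhibitor), compound 1 `CC(C)(C)OC(=O)NCCCCCN1C(Nc2ccc(-c3ccccc3)cc2)=Nc2ccccc2C1CC(=O)NCc1ccccc1` gives 170 nM, compound 2 `NCCCCCNC1=Nc2ccccc2C(CC(=O)NCc2ccccc2)N1c1ccc(-c2ccccc2)cc1` gives 130 nM, and compound 3 `COC(=O)CC1c2ccccc2N=C(NCCCCCN)N1c1ccc(-c2ccccc2)cc1` gives 560 nM, the highest of the three numbers, beyond the scatter from both others. Among the measured compounds shown here, the only single-place step measured so far, a 4.3-fold higher number from compound 2 to compound 3 (0.63 log units; beyond the scatter), arises from methoxy in place of benzylamino on a carbonyl carbon. Compound 4 `COC(=O)CC1c2ccccc2N=C(NCCCCCNC(=O)OC(C)(C)C)N1c1ccc(-c2ccccc2)cc1` differs from compound 3 by tert-butoxycarbonyl in place of hydrogen on an amine nitrogen. For the measured compounds named here, no measured step covers this change directly; compounds 1 and 2 carry the same chain amine with and without tert-butoxycarbonyl but differ elsewhere as well, and their two values sit within the scatter of each other. A step of no more than the scatter is therefore expected, so that a 1.1-fold lower number from compound 3 to compound 4 (0.05 log units; within the scatter). Compound 4 is estimated at 500 nM, with a range of 200 nM to 1300 nM.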

Compound 4, half-maximal inhibitory concentration: 680 nM
The estimate for compound 4 lay 1.4-fold (0.13 log units) below the measured number; the measured number falls inside the stated range.
By their numbers in this assay, from the lowest: compounds 2 and 1 (each within the scatter of the next); then compounds 3 and 4 (each within the scatter of the next).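

Among the compounds shown here, this is the first direct reading of the change on the chain amine: a 1.2-fold higher number from compound 3 to compound 4 (0.08 log units; within the scatter), so with the methyl ester in place, tert-butoxycarbonyl on this nitrogen gives a value that cannot be told apart from that of the free amine. A free amine at the chain end is therefore not needed to keep the number at this level in this pair. No supporting data bear on the reason for this result. Still open, on these data alone, is whether an acetyl group on the same nitrogen or a longer chain would read alike, and how a carboxylic acid in place of the methyl ester would behave.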